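This account rests on a few compounds, and the source may have more. Where it says the series, first, only, none or still open, it means among the compounds named here.

In a functional assay on PC-3 cells (Homo sapiens) for antiproliferative activity, read by MTT assay, with a stated time of 24 h (on this read-out lower numbers stand for stronger inhibition and higher numbers for weaker inhibition), compound 1 `CCn1c(C(=O)N[C@H](CO)CCO)ccc1C(CC)(CC)c1ccc(OCS(=O)(=O)c2ccccc2)c(C)c1` gives 12100 nM, and compound 2 `CCn1c(C(=O)N[C@@H](CO)CCO)ccc1C(CC)(CC)c1ccc(OCS(=O)(=O)c2ccccc2)c(C)c1` gives 14100 nM. Compound 3 `CCn1c(C(=O)N[C@@H](C)C(=O)O)ccc1C(CC)(CC)c1ccc(OCS(=O)(=O)c2ccccc2)c(C)c1` gives 16800 nM, which places it level with both within the scatter. Compound 4 `CCn1c(C(=O)N[C@H](CC(=O)O)C(=O)O)ccc1C(CC)(CC)c1ccc(OCS(=O)(=O)c2ccccc2)c(C)c1` has 1,2-dicarboxyethyl in place of 1-carboxyethyl on an amide-type nitrogen. The closest guides are the two measured swaps at that same nitrogen, a 1.4-fold higher number from compound 1 to compound 3 (0.14 log units; within the scatter) and a 1.2-fold higher number from compound 2 to compound 3 (0.08 log units; within the scatter). Neither leaves the scatter, and changing only the configuration as drawn, a 1.2-fold higher number from compound 1 to compound 2 (0.07 log units; within the scatter), does not either. No step beyond the scatter is therefore expected, and the expected change is a 1.1-fold higher number from compound 3 to compound 4 (0.03 log units; within the scatter). The estimate for compound 4 is 18000 nM, with an expected range from 9000 nM to 40000 nM.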

Compound 4, half-maximal inhibitory concentration: > 50000 nM
Compound 4 ended at the assay's limit; the forecaster's own chance of this, stated with the estimate: 10%; middle value at least 2.7-fold (0.44 log units) away from the limit.
By their numbers in this assay, from the lowest: compounds 1, 2 and 3 (each within the scatter of the next). At a limit, above all of these: compound 4.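

Going by these compounds alone, at this amide-type nitrogen, the change to 1,2-dicarboxyethyl is the first to leave the scatter, with an at least 2.9-fold higher number from compound 3 to compound 4 (0.47 log units; beyond the scatter), an at least 3.5-fold higher number from compound 2 to compound 4 (0.54 log units; beyond the scatter) and an at least 4.1-fold higher number from compound 1 to compound 4 (0.61 log units; beyond the scatter). Compound 4 gives > 50000 nM in this assay, which is a limit of the assay and not a number. So 1-carboxyethyl left compound 3 level with compounds 1 and 2, whereas 1,2-dicarboxyethyl did not keep compound 4 level with any of them.

Going by these compounds, how far compound 4 lies from the others stays open because its value is a limit: the limit of > 50000 nM in this assay, at which 1 of the 4 values shown sits. Also open is whether an amine or a longer chain ending in a carboxylic acid at this nitrogen would behave like 1-carboxyethyl or like 1,2-dicarboxyethyl.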